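A Second Methoxy on the Sulfonyl-Bound Ring

The compounds below may be only part of what the source reports. "The series", "measured", "known", "first", "only" and "open" are said of these compounds alone.

Compound 2 `COc1ccc(S(=O)(=O)n2cc(/C=N/N=C/N(C)C)c3c([N+](=O)[O-])cccc32)cc1` gives 740 nM in a functional assay on HEK293 cells for inhibition of 5-hydroxytryptamine receptor 6 (Homo sapiens), read by calcium flux and cAMP accumulation, with a stated time of 10 min; a higher number here means a weaker inhibitor, a lower number a stronger inhibitor. For the measured compounds named here, of the two numbers measured so far, that of compound 2 is the lower one. Going by the values given here, its only neighbour, compound 1 `CN(C)/C=N/N=C/c1cn(S(=O)(=O)c2ccc(F)cc2)c2cccc([N+](=O)[O-])c12`, gives 4970 nM in this assay. Among the compounds with values here, the single measured step, a 6.7-fold lower number from compound 1 to compound 2 (0.83 log units; beyond the scatter), put a methoxy in place of a fluoro on an aromatic carbon of the ring attached to the sulfonyl group.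

Compound 3 `COc1ccc(OC)c(S(=O)(=O)n2cc(/C=N/N=C/N(C)C)c3c([N+](=O)[O-])cccc32)c1` differs from compound 2 by 2,5-dimethoxyphenyl in place of 4-methoxyphenyl on a sulfonyl sulfur. Within the data shown here, the measured step bears on this only loosely: it shows that a methoxy on that ring, in place of a fluoro, went with a lower number, but no measured pair shows what a second methoxy, or a methoxy in another place, does. Expectation therefore leans on the observation that methoxy on this ring was tolerated, and a step of about the scatter, in either direction, is expected for compound 3. Compound 3 is estimated at 1000 nM in this assay, with a range from 300 nM to 3500 nM. This estimate means a step of a 1.4-fold higher number from compound 2 to compound 3 (0.13 log units; within the scatter), expected to stay within the scatter.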

Compound 3, half-maximal inhibitory concentration: 1400 nM
Beside the measured number, compound 3's estimate is 1.4-fold (0.15 log units) below it; measured number inside the range.
By their numbers in this assay, from the lowest: compounds 2 and 3 (each within the scatter of the next); then compound 1.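

In this assay, replacing 4-methoxyphenyl with 2,5-dimethoxyphenyl on the sulfonyl sulfur gave a 1.9-fold higher number from compound 2 to compound 3 (0.28 log units; within the scatter), so this assay cannot tell these two rings apart, even though the second carries an extra methoxy and a different substitution pattern. Against 4-fluorophenyl, the same change to 2,5-dimethoxyphenyl gave a 3.6-fold lower number from compound 1 to compound 3 (0.55 log units; beyond the scatter), and this second step is beyond the scatter. Two different methoxy-bearing rings now give lower numbers than the fluoro ring of compound 1, so the earlier gain is no longer tied to a single ring, although the three compounds are too few to establish a general rule. Nothing available explains why these rings give the numbers they do.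

The compounds shown leave open what each methoxy of the 2,5-dimethoxyphenyl ring contributes on its own, which a ring carrying only one of the two groups could help separate. Going by these compounds, it also remains open how this position would respond to a quite different group on the ring, such as an amine or a carboxylic acid.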